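A ring swap on a carbon double-bonded to nitrogen

The compounds below may be only part of what the source reports. "The series", "measured", "known", "first", "only" and "open" are said of these compounds alone.

Compound 1, `C/C(=N/Nc1nc(-c2ccc(C#N)cc2)cs1)c1cccs1`: 40%
Compound 2, `C/C(=N/Nc1nc(-c2ccc(C#N)cc2)cs1)c1cccnc1`: 40%
Compound 3, `Fc1ccc(-c2csc(N/N=C\c3cccs3)n2)c(F)c1`: 40%

All three were tested in an in vitro assay on BTI-TN-5B1-4 cells for inhibition of Amine oxidase [flavin-containing] A (Homo sapiens), read by Amplex Red, with a stated time of 15 min, tested at 100 uM; a lower number here means less inhibition, a higher number more inhibition at the concentration tested (going by the name of the read-out). Compound 2 differs from compound 1 by pyridin-3-yl in place of thiophen-2-yl on a carbon with a double bond to nitrogen, and that change gave no change at the digits printed from compound 1 to compound 2 (within the scatter). Compound 3 has a different core; the difference between the cores of compound 1 and compound 3 is not broken down here, yet in this assay compound 3 stands level with compound 1 and compound 2.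

Compound 4, `Fc1ccc(-c2csc(N/N=C\c3cccnc3)n2)c(F)c1`, is not yet measured. It differs from compound 3 by pyridin-3-yl in place of thiophen-2-yl on a carbon with a double bond to nitrogen. For the measured compounds named here, this is the same kind of change as from compound 1 to compound 2, not the same: in compound 1 the carbon also carries a saturated chain carbon, while in compound 3 its only other neighbour is the double-bonded nitrogen.

The expected step is no change at the digits printed from compound 3 to compound 4 (within the scatter), resting on the earlier step of no change at the digits printed from compound 1 to compound 2 (within the scatter), which stayed within the scatter. Compound 4 is therefore estimated at 40%, expected between 25% and 55%.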

Compound 4, a percentage reported as inhibition, at one concentration (the size of the read-out at that concentration, not a potency): 40%
Estimate against measurement, compound 4: no gap at the digits printed, within the range that was stated.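

Replacing thiophen-2-yl with pyridin-3-yl gave no change at the digits printed from compound 3 to compound 4 (within the scatter). In this assay, the swap therefore looks the same on both cores: the same change on two cores in this assay, no change at the digits printed (within the scatter) from compound 1 to compound 2 and no change at the digits printed (within the scatter) from compound 3 to compound 4, 0 percentage points apart, within the scatter of two such steps This shows that the swap carried across these two cores without a step beyond the scatter, but it does not show that the same would hold on any other core, and a percentage at one concentration says nothing about potency.

The compounds shown carry only thiophen-2-yl or pyridin-3-yl at this place. As far as these compounds go, whether a different group there, such as an amine or a longer chain, would shift the reading remains open.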